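This account rests on a few compounds, and the source may have more. Where it says the series, first, only, none or still open, it means among the compounds named here.

Compound 3 `O=C(O)COc1ccc(Cl)cc1C#Cc1ccc(Cl)s1` gives 183 nM in an assay on CHO cells for displacement of a labelled ligand from prostaglandin D2 receptor 2 (Homo sapiens), read by scintillation counting (on this read-out higher numbers stand for weaker inhibition and lower numbers for stronger inhibition), the highest of the three numbers measured. Compound 1 `O=C(O)COc1ccc(Cl)cc1C#Cc1ccccc1` gives 108 nM in this assay, and compound 2 `O=C(O)COc1ccc(Cl)cc1C#Cc1ccccc1Cl` gives 28 nM. Compound 4 `Cn1ccnc1C#Cc1cc(Cl)ccc1OCC(=O)O` differs from compound 3 as follows: 1-methyl-1H-imidazol-2-yl in place of 5-chlorothiophen-2-yl on a triple-bonded carbon. Two measured steps exchange the ring on the same triple-bonded carbon: a 1.7-fold higher number from compound 1 to compound 3 (0.23 log units; within the scatter) and a 6.5-fold higher number from compound 2 to compound 3 (0.82 log units; beyond the scatter), neither of them involving a 1-methyl-1H-imidazol-2-yl group. The entering ring carries no chlorine, whereas in the step of a 3.9-fold lower number from compound 1 to compound 2 (0.59 log units; beyond the scatter) a chloro was gained, so a rise beyond the scatter is expected here, a 2.5-fold higher number from compound 3 to compound 4 (0.39 log units; beyond the scatter), though the precedent is thin. Compound 4 is therefore estimated at 450 nM, with a range from 120 nM to 1700 nM.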

Compound 4, inhibition constant: 1470 nM
Estimate against measurement, compound 4: 3.3-fold (0.51 log units) below, within the range that was stated.
By their numbers in this assay, from the lowest: compound 2; then compounds 1 and 3 (each within the scatter of the next); then compound 4.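

On this triple-bonded carbon, the 1-methyl-1H-imidazol-2-yl group raises the number against every earlier ring (an 8.0-fold higher number from compound 3 to compound 4 (0.90 log units; beyond the scatter); a 14-fold higher number from compound 1 to compound 4 (1.13 log units; beyond the scatter); a 53-fold higher number from compound 2 to compound 4 (1.72 log units; beyond the scatter)). The position therefore does not accept every five-membered aromatic ring equally: compound 4 stands beyond the scatter of all three others, while phenyl and 5-chlorothiophen-2-yl remain within the scatter of each other. Nothing available here bears on why this exchange has so large an effect.

Whether the methyl or the second ring nitrogen accounts for the rise stays open. So does whether a 1H-imidazol-2-yl ring without the methyl, or a chloro on the imidazole, would bring the number back down.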